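Trading an allylcarbamoyl arm for ethoxycarbonyl

A few compounds are considered here, and "the series" means these few. Any claim that something is new, unique, unknown or untested is made for them only; others in the source may bear on it.

In a functional assay on MCF7 cells (Homo sapiens) for inhibition (on this read-out lower numbers stand for stronger inhibition and higher numbers for weaker inhibition), compound 3 `C=CCNC(=O)COC1=CC(=O)S[C@]1(C)CCCCCCCC` reads > 50 ug/mL, which is a limit and not a number. Compound 2 `C=CCOC1=CC(=O)S[C@]1(C)CCCCCCCC` reads > 50 ug/mL, also a limit. Compound 1 `CCCCCCCC[C@@]1(C)SC(=O)C=C1OCC(=O)OCC` gives a true number, 10.8 ug/mL. Two measured steps away from it bear on what follows, both beyond the scatter: an at least 4.6-fold higher number from compound 1 to compound 2 (0.66 log units; beyond the scatter), and an at least 4.6-fold higher number from compound 1 to compound 3 (0.66 log units; beyond the scatter).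

The change to compound 4 `CCCCCCCC[C@@]1(C)SC(=O)C=C1OC(=O)OCC` is ethoxycarbonyl in place of (allylcarbamoyl)methyl on an oxygen on an unsaturated carbon. Compound 1, at 10.8 ug/mL, also carries ethoxycarbonyl, although on a saturated chain carbon. A step toward stronger inhibition is therefore expected, an at least 2.2-fold lower number from compound 3 to compound 4 (0.35 log units; beyond the scatter). Compound 4 is estimated at 22 ug/mL, with an expected range of 8 ug/mL to 50 ug/mL.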

Compound 4, half-maximal inhibitory concentration: 14.5 ug/mL
Estimate against measurement, compound 4: 1.5-fold (0.18 log units) above; measured number inside the range.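

On the oxygen on an unsaturated carbon, ethoxycarbonyl gives a true number in this assay, with an at least 3.4-fold lower number from compound 3 to compound 4 (0.53 log units; beyond the scatter) and an at least 3.4-fold lower number from compound 2 to compound 4 (0.53 log units; beyond the scatter). Both of these steps start from a limit and not from a number, so they give only a minimum size: the limit of > 50 ug/mL in this assay, at which 2 of the 4 values shown sit. Ethoxycarbonyl and (ethoxycarbonyl)methyl on that oxygen read alike, with a 1.3-fold higher number from compound 1 to compound 4 (0.13 log units; within the scatter), so among these compounds only those two groups give true numbers.

From the compounds shown here alone, it remains open whether a carboxylic acid in place of the ethoxycarbonyl ester, or a longer chain in place of its ethyl, would also give a true number.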